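Methyl to Nitro on a Shared Benzothiazole-Type Amine Series

A few compounds are considered here, and "the series" means these few. Any claim that something is new, unique, unknown or untested is made for them only; others in the source may bear on it.

Measured compounds:
compound 1, `Cc1ccc2nc(NC(=O)/C=C/OC3=CC=C3)sc2c1`: 505 umol/kg
compound 2, `O=C(/C=C/OC1=CC=C1)Nc1nc2ccc([N+](=O)[O-])cc2s1`: 597 umol/kg
compound 3, `CC(=O)N1N=C(Nc2nc3ccc(C)cc3s2)CC1c1ccccc1`: 106 umol/kg

In a functional assay on the whole organism (Hindlimb, strain albino) with Mus musculus as the target, in the maximal electroshock model, with a stated time of 0.5 h (on this read-out lower numbers stand for an effect already at smaller amounts and higher numbers for an effect only at larger amounts of compound), compound 1 gives 505 umol/kg and compound 2 gives 597 umol/kg. The two differ only by nitro in place of methyl on an aromatic carbon, and the step of a 1.2-fold higher number from compound 1 to compound 2 (0.07 log units; within the scatter) is within the scatter, so the two numbers cannot be told apart. Compound 3 gives 106 umol/kg in this assay, the lowest of the three numbers, with the gaps to compound 1 and compound 2 both beyond the scatter; how the core of compound 3 differs from the core of compound 1 is not broken down here.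

Compound 4, `CC(=O)N1N=C(Nc2nc3ccc([N+](=O)[O-])cc3s2)CC1c1ccccc1`, has not yet been measured. It differs from compound 3 by nitro in place of methyl on an aromatic carbon, the same change, at the same place, that separates compound 1 from compound 2. If that change behaves alike on the core of compound 3, the expected step is a 1.2-fold higher number from compound 3 to compound 4 (0.09 log units; within the scatter), resting on the single earlier step of a 1.2-fold higher number from compound 1 to compound 2 (0.07 log units; within the scatter). Compound 4 is therefore estimated at 130 umol/kg in this assay, within a range from 60 umol/kg to 280 umol/kg.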

Compound 4, dose for half-maximal effect: 216 umol/kg
The estimate for compound 4 lay 1.7-fold (0.22 log units) below the measured number, and the stated range covers the measured number.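

On the core of compound 3, nitro in place of methyl on an aromatic carbon gives a 2.0-fold higher number from compound 3 to compound 4 (0.31 log units; beyond the scatter) in this assay, a modest step. Set beside the earlier step on the core of compound 1, it does not differ by more than repeated measurements of this kind allow, so the two cores give no sign that this change behaves differently from one to the other: the same change on two cores in this assay, a 1.2-fold higher number (0.07 log units; within the scatter) from compound 1 to compound 2 and a 2.0-fold higher number (0.31 log units; beyond the scatter) from compound 3 to compound 4, 1.7-fold (0.24 log units) apart, within the scatter of two such steps This rests on a single pair of compounds on each core, so it does not show that the change would carry over alike to any further core, and it gives no reason why only the step on the core of compound 3 lies beyond the scatter.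

The compounds shown carry only methyl or nitro at this place, so it remains open how an amine, a methoxy group or a carboxylic acid there would compare. From the compounds shown here alone, it also remains open how a longer chain there would fare on either core.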